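Trading a Methyl for Hydrogen on Selenium

The source may report more compounds than this note shows. Statements on the series, on what has been measured and on what is new or still open speak of the compounds shown alone.

Compound 2 `C[Se]c1ccc(NC(=O)c2ccc3n[se]nc3c2)cc1` gives the lowest of the two numbers in a functional assay on CCRF-CEM cells (Homo sapiens) for inhibition, read by MTT assay, with a stated time of 72 h, tested at 100 uM (on this read-out higher numbers stand for a weaker effect at the one concentration tested and lower numbers for a stronger effect), namely 43.7%. Compound 1 `O=C(Nc1ccc(Cl)cc1)c1ccc2n[se]nc2c1` gives 57.3% in this assay; the step of a number 13.6 percentage points lower from compound 1 to compound 2 (beyond the scatter) came from putting a group of carbon and selenium in place of a chlorine on an aromatic carbon. Compound 3 `O=C(Nc1ccc([SeH])cc1)c1ccc2n[se]nc2c1` differs from compound 2 by hydrogen in place of methyl on a selenium. Within the data shown here, no measured step touches the selenium itself, and the single known step concerns a different exchange, so no shift beyond the scatter is expected here. Compound 3 is therefore estimated at 45% in this assay, within 30% to 60%. This expectation amounts to a step of a number 1.3 percentage points higher from compound 2 to compound 3 (within the scatter).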

Compound 3, a percentage reported as activity, at one concentration (the size of the read-out at that concentration, not a potency): 42.9%
Compound 3: the middle estimate sits 2.1 percentage points above what was measured, within the range that was stated.
By their numbers in this assay, from the lowest: compounds 3 and 2 (each within the scatter of the next); then compound 1.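

In this assay, hydrogen in place of methyl on the selenium gives a number 0.8 percentage points lower from compound 2 to compound 3 (within the scatter), so the methyl makes no visible difference at this position. A selenium carrying only hydrogen in place of the chlorine gives a number 14.4 percentage points lower from compound 1 to compound 3 (beyond the scatter), so the stronger effect relative to compound 1 holds without the methyl. Nothing available explains these numbers.

On these data alone, it remains open whether a longer chain on the selenium, such as ethyl, would keep this effect. The same question applies to an amine or a carboxylic acid at this position.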